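Methoxy in place of trifluoromethyl: one open measurement

The source may report more compounds than this note shows. Statements on the series, on what has been measured and on what is new or still open speak of the compounds shown alone.

Results in a functional assay on HCT-116 cells (Homo sapiens) for cytotoxicity (a higher number here means that more compound is needed for the effect, a lower number that less compound is needed), stand as follows
compound 1 `CC(=O)SCC(=O)c1ccc(NS(=O)(=O)c2ccccc2)cc1` gives 15400 nM
compound 2 `CC(=O)SCC(=O)c1ccc(NS(=O)(=O)c2ccccc2Cl)cc1` gives "not determined" (no result reported)
compound 3 `CC(=O)SCC(=O)c1ccc(NS(=O)(=O)c2ccc(C(F)(F)F)cc2)cc1` gives "not determined" (no result reported)

Within the data shown here, only one compound in this small set carries a number. Among the measured compounds shown here, compound 3 has no single value to its name, and compound 2 is the only other compound left in that position. For the measured compounds named here, neither can be placed above or below compound 1, and no pair of measured compounds shows what a single structural change does here.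

Compound 4 `COc1ccc(S(=O)(=O)Nc2ccc(C(=O)CSC(C)=O)cc2)cc1` has not yet been measured. The change methoxy in place of trifluoromethyl on an aromatic carbon puts methoxy in place of trifluoromethyl on an aromatic carbon, para to a large group. With no number at the starting point, this change cannot be sized directly from the data. In this assay, going by the values given here, the expectation is therefore of no step beyond the usual scatter, in neither direction, with the sole number as the anchor. That anchor is compound 1 (15400 nM), and it is a thin basis, so the range is kept wide. Compound 4 is estimated at 15000 nM (expected range 5000 nM to 45000 nM).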

Compound 4, half-maximal effective concentration: 500 nM
Estimate against measurement, compound 4: 30-fold (1.48 log units) above, outside the stated range (below it).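

Among these compounds, compound 1 and compound 4 form the first pair in this set with a number at both ends, and in this assay they show that the position on an aromatic carbon, para to a large group, is not a silent one: methoxy in place of hydrogen there gives a 31-fold lower number from compound 1 to compound 4 (1.49 log units; beyond the scatter) in this single pair. Compound 3 carries no number, so the step from trifluoromethyl to methoxy cannot be read, and the size seen here belongs only to the change from hydrogen to methoxy. No measurement shown accounts for the size of this step.

As far as these compounds go, compound 2 and compound 3 still cannot be placed against compound 1 or compound 4, so it stays open whether chlorine or trifluoromethyl on the same ring would move the number in the same direction as methoxy. One pair also cannot tell whether the gain is particular to methoxy or would extend to other groups at this position, such as an amine, a carboxylic acid or a longer chain like ethoxy.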